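The source may report more compounds than this note shows. Statements on the series, on what has been measured and on what is new or still open speak of the compounds shown alone.

Working notes on the series. The shared core is a tricyclic quinone bearing an amine substituent; compound 1 `Cc1ccc(NC2=CC(=O)c3c(nc4n3[C@H]3OC[C@@H](O)[C@H]3OC4)C2=O)cc1C` carries 3,4-dimethylphenyl on that nitrogen, compound 2 `O=C1C=C(Nc2cccc(F)c2)C(=O)c2c1nc1n2[C@H]2OC[C@@H](O)[C@H]2OC1` a 3-fluorophenyl, and compound 3 `O=C1C(NCc2ccccc2)=CC(=O)c2c1nc1n2[C@H]2OC[C@@H](O)[C@H]2OC1` a benzyl. In a functional assay on HeLa cells (Homo sapiens) for inhibition, read by sulforhodamine B assay (on this read-out higher numbers stand for weaker inhibition and lower numbers for stronger inhibition), compound 1 gives 4320 nM, compound 2 gives 6440 nM and compound 3 gives 11000 nM. Among the compounds with values here, compound 2 therefore sits between the other two, but its gaps to compound 1 and to compound 3 are both within the scatter, so nothing separates these three except the single step of a 2.5-fold higher number from compound 1 to compound 3 (0.41 log units; beyond the scatter), which is the only one that reaches beyond the scatter.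

Compound 4 `O=C1C=C(Nc2ccc(I)cc2)C(=O)c2c1nc1n2[C@H]2OC[C@@H](O)[C@H]2OC1` is not yet measured. It differs from compound 2 as follows: 4-iodophenyl in place of 3-fluorophenyl on an amine nitrogen. Within the data shown here, no measured step moves one aryl substituent to another, so the only guide is that compound 1 and compound 2, which differ in the substituent on the phenyl ring, return numbers within the scatter of each other. On that basis the step to compound 4 in this assay is expected to stay within the scatter, in no particular direction, which is what a 1.2-fold lower number from compound 2 to compound 4 (0.07 log units; within the scatter) expresses. Compound 4 is therefore estimated at 5500 nM, with a range of 2500 nM to 12000 nM.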

Compound 4, half-maximal inhibitory concentration: 4070 nM
Estimate against measurement, compound 4: 1.4-fold (0.13 log units) above; the measured number falls inside the stated range.
By their numbers in this assay, from the lowest: compounds 4, 1, 2 and 3 (each within the scatter of the next, the first and the last beyond it).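

Within the data shown here, the step of a 1.6-fold lower number from compound 2 to compound 4 (0.20 log units; within the scatter) in this assay is the only direct comparison in hand that exchanges one aryl group for another on the amine nitrogen, and it stays within the scatter. This position therefore accepts 3-fluorophenyl and 4-iodophenyl, both of 7 heavy atoms, with no separable difference in this read-out, even though the halogen and its place on the phenyl ring change in the same step. Nothing available accounts for this outcome, and it gives no reason to attach meaning to the direction of the step.

Since the element and its ring position change together, the step cannot show what each contributes alone, and a small step here could equally hide two opposing contributions. Also open, going by these compounds, is whether the insensitivity holds beyond simple aryl substituents: a carboxylic acid or a dimethylamino group on the phenyl ring, a pyridine in place of the phenyl ring, or a longer chain such as phenethyl in place of benzyl would test how far this position can be changed.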